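Piperidine amide to sulfonamidobutyl amide at the glycine carbonyl

The source may report more compounds than this note shows. Statements on the series, on what has been measured and on what is new or still open speak of the compounds shown alone.

Measured compounds:
Compound 1 `CCC1CCCN(C(=O)CN2CN(c3ccccc3)C3(CCN(C(=O)c4ccc(C(C)(C)C)cc4)CC3)C2=O)C1` gives 3900 nM in an assay on HEK293 cells for displacement of a labelled ligand from NPC1-like intracellular cholesterol transporter 1 (Homo sapiens); a lower number here means a stronger inhibitor, a higher number a weaker inhibitor.
For compound 2 `COC(=O)CCNC(=O)CN1CN(c2ccccc2)C2(CCN(C(=O)c3ccc(C(C)(C)C)cc3)CC2)C1=O` the result in this assay is "not determined" (no result reported).
Compound 3 `CC1CCCN(C(=O)CN2CN(c3ccccc3)C3(CCN(C(=O)c4ccc(C(C)(C)C)cc4)CC3)C2=O)C1` gives 12000 nM in this assay.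

For the measured compounds named here, compound 3 holds the highest number of the two values known; its nearest neighbour is compound 1, reached by the step of a 3.1-fold higher number from compound 1 to compound 3 (0.49 log units; beyond the scatter), the only single-point step in the set.

Compound 4 `CC(C)(C)c1ccc(C(=O)N2CCC3(CC2)C(=O)N(CC(=O)NCCCCNS(C)(=O)=O)CN3c2ccccc2)cc1` differs from compound 3 in one place: (4-(methanesulfonamido)butyl)amino in place of 3-methylpiperidin-1-yl on a carbonyl carbon

Going by the values given here, no measured step bears directly on this change. Among the compounds with values here, the one step known, a 3.1-fold higher number from compound 1 to compound 3 (0.49 log units; beyond the scatter), concerns only the methyl on the saturated ring and says nothing about replacing the whole 3-methylpiperidin-1-yl group with (4-(methanesulfonamido)butyl)amino. The change is large in atom count and in donors and acceptors, so the direction is open and the uncertainty wide. Compound 4 is expected near compound 3, with the step of a 1.5-fold lower number from compound 3 to compound 4 (0.18 log units; within the scatter) as the central guess. The estimate for compound 4 is 8000 nM, with a range from 2000 nM to 40000 nM.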

Compound 4, half-maximal inhibitory concentration: 4500 nM
The estimate for compound 4 lay 1.8-fold (0.25 log units) above the measured number, within the range that was stated.
By their numbers in this assay, from the lowest: compounds 1 and 4 (each within the scatter of the next); then compound 3.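

At the carbonyl carbon, a piperidine ring is not needed to keep a number of this order in this assay. The open-chain (4-(methanesulfonamido)butyl)amino group, which has no ring and carries hydrogen-bond donors where 3-methylpiperidin-1-yl has none, gives a 2.7-fold lower number from compound 3 to compound 4 (0.43 log units; beyond the scatter), and against 3-ethylpiperidin-1-yl it gives a 1.2-fold higher number from compound 1 to compound 4 (0.06 log units; within the scatter), so the chain matches the ethyl-bearing ring amide and not merely the weaker methyl-bearing one. Nothing at hand explains either step.

Which part of the new group carries this result stays open, since the butyl chain and the methanesulfonamido end enter together, and a plain butylamino group, a longer chain or a terminal carboxylic acid would separate the two. Steps to compound 2 cannot be read.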